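Amide replacement on compound 2: expected step size

The compounds below may be only part of what the source reports. "The series", "measured", "known", "first", "only" and "open" are said of these compounds alone.

In an assay on HEK293 cells for positive allosteric modulation of metabotropic glutamate receptor 5 (Homo sapiens), read by FLIPR, with a stated time of 1 h (a higher number here means that more compound is needed for the effect, a lower number that less compound is needed), compound 2 `O=C(C1CC12CCC2)N1CCc2nc(C#Cc3ccccc3)sc2C1` gives 3.9 nM, the only number shown in this set. Compound 1 `Cc1cccc(C#Cc2nc3c(s2)C(=O)NCC3)c1` reaches only a limit of this assay, > 10000 nM, as stated in the limit of > 10000 nM in this assay, at which 1 of the 2 values shown sits. Compound 3 `Cc1cccc(C(=O)N2CCc3nc(C#Cc4ccccc4)sc3C2)n1` is not yet measured; it differs from compound 2 at one place: a group of 7 heavy atoms (6 carbon, 1 nitrogen; one six-membered aromatic ring with 1 hetero atom) in place of a group of 6 heavy atoms (6 carbon; one three-membered non-aromatic ring of carbon only, one four-membered non-aromatic ring of carbon only), on a carbonyl carbon. No step between measured compounds is shown, so nothing measured guides this exchange. The expected step of a 2.1-fold higher number from compound 2 to compound 3 (0.31 log units; beyond the scatter) is small, toward needing somewhat more compound, and probably not beyond the scatter. Compound 3 is expected to give about 8 nM, within 2 nM to 40 nM.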

Compound 3, half-maximal effective concentration: 160 nM
Estimate against measurement, compound 3: 20-fold (1.30 log units) below, and the stated range ends below it.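

In this assay, the position on the carbonyl carbon responds strongly to this change: 6-methylpyridin-2-yl, replacing the group of carbon-only three- and four-membered rings, gives a 41-fold higher number from compound 2 to compound 3 (1.61 log units; beyond the scatter). The amide substituent is therefore not interchangeable in this series, at least for this pair. Nothing shown gives a cause for this step.

A single pair cannot separate the contributions of the aromatic ring, its nitrogen and its methyl group. From the compounds shown here alone, whether a phenyl or a plain cyclobutyl on the same carbonyl carbon would stand closer to compound 2 or compound 3 remains open.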